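One group exchanged on a shared core

A few compounds are considered here, and "the series" means these few. Any claim that something is new, unique, unknown or untested is made for them only; others in the source may bear on it.

Of the compounds shown here, three built on a shared core have been measured in a physicochemical assay for lipophilicity, at pH 7.4; on this read-out higher numbers stand for higher lipophilicity and lower numbers for lower lipophilicity. Compound 3 (`Cc1cc(C)c(CN2CCc3c(Cl)cc([C@@H](CO)[C@@H]4CCCO4)c(Cl)c3C2=O)c(=O)[nH]1`) gives 2.1, the lowest number of the three. Compound 1 (`COc1cc(C)[nH]c(=O)c1CN1CCc2c(Cl)cc(-c3c(C)noc3C)c(Cl)c2C1=O`) comes nearest at 2.7, and that gap lies beyond the usual scatter of repeated measurements. Compound 2 (`COC(c1cc(Cl)c2c(c1Cl)C(=O)N(Cc1c(C)cc(C)[nH]c1=O)CC2)C1CCOCC1`) was measured twice and gives 3.4; 3.5 (2 entries).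

Compound 4 (`Cc1cc(C)c(CN2CCc3c(Cl)cc(-c4c(C)noc4C)c(Cl)c3C2=O)c(=O)[nH]1`) has not yet been measured. Its structure differs from that of compound 3 in one place: a group of 7 heavy atoms (5 carbon, 1 nitrogen, 1 oxygen; one five-membered aromatic ring with 2 hetero atoms) in place of a group of 8 heavy atoms (6 carbon, 2 oxygen; one five-membered non-aromatic ring with 1 hetero atom), on an aromatic carbon. The exchange sits on an aromatic carbon, ortho to a chloro group. Among the measured compounds shown here, no measured pair of compounds shows this exchange directly, so the forecast has to lean on a close relative. Compound 1 already carries the entering 3,5-dimethyl-1,2-oxazol-4-yl group and gives 2.7, although it also differs from compound 4 at one other place. On that basis, a rise in this assay beyond the scatter is expected, with an estimated size of a number 0.90 log units higher from compound 3 to compound 4 (beyond the scatter). For compound 4 the estimated value is 3, with an expected range from 2.6 to 3.4.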

Compound 4, distribution coefficient: 3.1
Compound 4: the middle estimate sits 0.10 log units below what was measured; the range from low to high includes it.
By their numbers in this assay, from the lowest: compound 3; then compound 1; then compound 4.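

In this assay, among the compounds shown here, replacing the group of 8 heavy atoms, with its five-membered non-aromatic ring and 2 defined stereocentres, by 3,5-dimethyl-1,2-oxazol-4-yl gives a number 1.00 log units higher from compound 3 to compound 4 (beyond the scatter), the first direct reading of an exchange at this aromatic carbon, ortho to a chloro group. For the compounds shown here, compound 4 also gives a first reading at a second place on the molecule: methyl in place of methoxy on an aromatic carbon gives a number 0.40 log units higher from compound 1 to compound 4 (beyond the scatter), so the read-out responds measurably to a change at either place. Going by these compounds alone, the only supporting information here concerns the repeat entries of compound 2, and no measurement explains why either step has its size.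

As far as these compounds go, only these two groups can be compared directly at the position ortho to a chloro group, so it remains open how the read-out would respond to a simple amine, a carboxylic acid or a longer chain there. From the compounds shown here alone, the methyl and methoxy exchange is read on a single pair, and whether it gives a step of similar size alongside a different group at the first position also remains open.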